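The compounds below may be only part of what the source reports. "The series", "measured", "known", "first", "only" and "open" are said of these compounds alone.

Working notes on the series, all read in an assay on isolated protein for inhibition of histone deacetylase 4 (Homo sapiens), tested at 1 uM; on this read-out higher numbers stand for more inhibition at the one concentration tested (going by the name of the read-out) and lower numbers for less inhibition.

Of the compounds shown here, three have numbers so far. Compound 1, `CC(C)(C(=O)Nc1ccc(C(=O)Nc2ccc(F)cc2N)cc1)c1ccccc1`, gives 0%. Compound 2, `CC(C)[C@@H](C(=O)Nc1ccc(C(=O)Nc2ccccc2N)cc1)c1ccccc1`, gives 9%. Compound 3, `CC(C)[C@@H](C(=O)Nc1ccc(C(=O)Nc2ccc(C(F)(F)F)cc2N)cc1)c1ccccc1`, gives 3%. Compound 3 thus stands second highest of the three, with compound 1 nearest and compound 2 furthest, yet both gaps lie within the scatter, so no order among the three can be read from these numbers.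

One single-point step is known: a number 6 percentage points lower from compound 2 to compound 3 (within the scatter). It shows that placing a trifluoromethyl where hydrogen stood left this assay unchanged beyond the scatter.

Compound 4, `CC(C)[C@@H](C(=O)Nc1ccc(C(=O)Nc2ccc(F)cc2N)cc1)c1ccccc1`, is not yet measured. It differs from compound 3 in one place: fluoro in place of trifluoromethyl on an aromatic carbon. Within the data shown here, no measured pair shows a fluoro replacing a trifluoromethyl, so the known step bears only indirectly; it suggests that changes at this aromatic carbon do not move this assay beyond the scatter. The expected step is therefore no change at the digits printed from compound 3 to compound 4 (within the scatter), essentially none. For compound 4 the estimate is 3%, with a range from -7% to 13%.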

Compound 4, a percentage reported as inhibition, at one concentration (the size of the read-out at that concentration, not a potency): 0%
Compound 4: the middle estimate sits 3 percentage points above what was measured; the range from low to high includes it.
By their numbers in this assay, from the lowest: compounds 1, 4, 3 and 2 (each within the scatter of the next).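

In this assay, this aromatic carbon now carries hydrogen, fluoro or trifluoromethyl on the same core, and no exchange among them moves the number beyond the scatter: fluoro in place of trifluoromethyl gives a number 3 percentage points lower from compound 3 to compound 4 (within the scatter), and fluoro in place of hydrogen gives a number 9 percentage points lower from compound 2 to compound 4 (within the scatter). The series also gains its first single-point comparison at the carbonyl carbon, where 2-methyl-1-phenylpropyl in place of 1-methyl-1-phenylethyl gives no change at the digits printed from compound 1 to compound 4 (within the scatter). No supporting data bear on these results.

Still open, going by these compounds, is whether an amine or a carboxylic acid on this aromatic carbon, or a longer chain on the carbonyl carbon, would shift the number beyond the scatter. With every step so far within the scatter, the compounds shown do not establish that either position affects this assay at all.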